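The source may hold more compounds than are shown below. What is called first, only, known or untested is meant among the compounds shown, and "the series" means these compounds.

Working notes on the series. In a functional assay on the whole organism (strain Wistar) for inhibition, with Rattus norvegicus as the target (a lower number here means that less compound is needed, a higher number that more compound is needed for the effect), compound 1 (`CCc1ccc2c(O)c(C#N)c(=O)oc2c1`) gives 23.8 umol/kg and compound 2 (`CCc1cc2c(O)c(C#N)c(=O)oc2cc1C`) gives 10.1 umol/kg. Compound 2 therefore holds the lower of the two numbers, and its gap to compound 1 lies beyond the scatter. These two compounds do not isolate a single structural change.

Compound 3 (`CCc1cc2oc(=O)c(C#N)c(O)c2cc1CC`) remains to be measured. Relative to compound 2, it has methyl in place of hydrogen on a saturated chain carbon bound to an aromatic carbon. The same difference, cut one bond further out, reads methyl to ethyl. For the measured compounds named here, no measured pair shows this change alone, so no shift beyond the scatter is expected in this assay, and neither direction is favoured. The expected change is a 1.1-fold lower number from compound 2 to compound 3 (0.05 log units; within the scatter). For compound 3 the estimated value is 9 umol/kg, with an expected range of 3.5 umol/kg to 23 umol/kg.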

Compound 3, dose for half-maximal effect: 7.6 umol/kg
Beside the measured number, compound 3's estimate is 1.2-fold (0.07 log units) above it; the measured number falls inside the stated range.
By their numbers in this assay, from the lowest: compounds 3 and 2 (each within the scatter of the next); then compound 1.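

In this assay, for the compounds shown here, methyl in place of hydrogen on a saturated chain carbon bound to an aromatic carbon gives a 1.3-fold lower number from compound 2 to compound 3 (0.12 log units; within the scatter) as the first reading of this change alone, so going from methyl to ethyl at this place does not carry the number outside the scatter. Ethyl in place of hydrogen on an aromatic carbon gives a 3.1-fold lower number from compound 1 to compound 3 (0.50 log units; beyond the scatter) and is the first single-place step in the series to lie beyond the scatter, though only modestly. Nothing at hand explains the size of either step.

On these data alone, whether a longer chain such as propyl at this place would shift the number beyond the scatter remains open. Also open, as far as these compounds go, is how an amine or a carboxylic acid would read on the same aromatic carbon, in place of ethyl.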